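This account rests on a few compounds, and the source may have more. Where it says the series, first, only, none or still open, it means among the compounds named here.

In a functional assay on MCF7 cells (Homo sapiens) for cytotoxicity, read by MTT assay, with a stated time of 24 h (a lower number here means a stronger inhibitor, a higher number a weaker inhibitor), compound 3 `CN(C)/C=C/N1CCN(CC(=O)Nc2ccc(-c3nc(-c4ccccc4)c(-c4ccccc4)n3C)cc2)CC1` gives 80 ug/mL, the highest number of the three measured. Compound 1 `Cn1c(-c2ccc(NC(=O)CSc3nc4ccccc4o3)cc2)nc(-c2ccccc2)c1-c1ccccc1` gives 11.2 ug/mL and compound 2 `Cc1nnc(SCC(=O)Nc2ccc(-c3nc(-c4ccccc4)c(-c4ccccc4)n3C)cc2)s1` gives 3.2 ug/mL; the steps of a 7.1-fold higher number from compound 1 to compound 3 (0.85 log units; beyond the scatter) and a 25-fold higher number from compound 2 to compound 3 (1.40 log units; beyond the scatter) both run the same way, while a 3.5-fold lower number from compound 1 to compound 2 (0.54 log units; beyond the scatter) separates the two lower numbers. Compound 4 `Cn1c(-c2ccc(NC(=O)CN3CCN(Cc4ccc(Cl)cc4)CC3)cc2)nc(-c2ccccc2)c1-c1ccccc1` differs from compound 3 by 4-chlorobenzyl in place of 2-(dimethylamino)ethenyl on an amine nitrogen in a ring. Among the measured compounds shown here, no measured step alters only the substituent on that ring nitrogen; the two steps leading to compound 3 replace the whole group on the chain carbon, so they bear on this change only indirectly. A change no larger than modest is therefore expected, direction uncertain, a lower number slightly favoured. Compound 4 is estimated at 40 ug/mL, range 10 ug/mL to 160 ug/mL, which means an expected step of a 2.0-fold lower number from compound 3 to compound 4 (0.30 log units; within the scatter) in this assay.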

Compound 4, half-maximal inhibitory concentration: 21 ug/mL
The estimate for compound 4 lay 1.9-fold (0.28 log units) above the measured number, within the range that was stated.
By their numbers in this assay, from the lowest: compound 2; then compounds 1 and 4 (each within the scatter of the next); then compound 3.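

In this assay, the change confined to the amine nitrogen in the ring gives a 3.8-fold lower number from compound 3 to compound 4 (0.58 log units; beyond the scatter), so 4-chlorobenzyl in place of 2-(dimethylamino)ethenyl at this position alone moves the number beyond the scatter. The earlier steps shown here replaced the whole group on the chain carbon and could not isolate this nitrogen substituent. No measurement at hand bears on what lies behind the step.

As far as these compounds go, whether the lower number depends on the aromatic ring or on the chlorine stays open. An unsubstituted benzyl or a methyl on the same nitrogen would separate these.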